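This account rests on a few compounds, and the source may have more. Where it says the series, first, only, none or still open, it means among the compounds named here.

Measured compounds:
Compound 1, `Cn1c(-c2cccc(Cl)c2)nc2c(NC3CCCC3)ncnc21`, gives 6.5 nM.
Compound 2, `CCCn1c(-c2ccccc2)nc2c(N)ncnc21`, gives 101 nM.

Both numbers come from an assay on CHO cells for displacement of a labelled ligand from adenosine receptor A1 (Homo sapiens), read by scintillation counting, with a stated time of 3 h; a lower number here means a stronger inhibitor, a higher number a weaker inhibitor. Going by the values given here, of the two values known so far, compound 1 holds the lower number, and the gap to compound 2 lies beyond the scatter of repeated measurements. Compound 3, `Cc1cccc(-c2nc3c(NC4CCCC4)ncnc3n2C)c1`, has not yet been measured in this assay. It differs from compound 1 in a single place: methyl in place of chloro on an aromatic carbon. Among the compounds with values here, no pair of measured compounds differs in just one place, so there is no measured step to lean on for this change. An exchange of chloro for methyl on an aromatic carbon usually moves a number of this kind only a little. The step from compound 1 to compound 3 is therefore expected to be small, a 1.2-fold higher number from compound 1 to compound 3 (0.09 log units; within the scatter), most likely within the scatter. Compound 3 is estimated to give 8 nM, with a likely range from 3 nM to 22 nM.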

Compound 3, inhibition constant: 6.2 nM
Beside the measured number, compound 3's estimate is 1.3-fold (0.11 log units) above it; measured number inside the range.
By their numbers in this assay, from the lowest: compounds 3 and 1 (each within the scatter of the next); then compound 2.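

In this assay, going by these compounds alone, the exchange of 3-chlorophenyl for 3-methylphenyl gives a 1.0-fold lower number from compound 1 to compound 3 (0.02 log units; within the scatter), the first measured step between compounds that differ in one place. At this place on the ring, meta to a large group, the read-out does not separate chloro from methyl, so the low number of compound 1 does not depend on chloro being present: with methyl there, compound 3 gives 6.2 nM. No measurement available here accounts for the two groups reading alike.

The compounds shown leave open how this position responds to groups of a different kind, such as a hydroxyl, an amine or a carboxylic acid, or to a longer chain. They also leave open whether the same exchange of chloro for methyl would read alike at another place on the ring.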